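Methoxy for chloro: from compound 3 to compound 4

The compounds below may be only part of what the source reports. "The series", "measured", "known", "first", "only" and "open" are said of these compounds alone.

In a functional assay on MV4-11 cells (Homo sapiens) for antiproliferative activity, read by CCK-8 assay, with a stated time of 72 h (a higher number here means a weaker inhibitor, a lower number a stronger inhibitor), compound 3 (`Cn1cc(-c2cccc(Cl)c2)c2cc(C(=O)NCc3ccc(C(=O)Nc4ccccc4N)cc3)[nH]c2c1=O`) gives 190 nM. That value lies within the scatter of compound 2 (`Cn1cc(-c2cccc(F)c2)c2cc(C(=O)NCc3ccc(C(=O)Nc4ccccc4N)cc3)[nH]c2c1=O`) at 210 nM and of compound 1 (`COc1cccc(-c2cn(C)c(=O)c3[nH]c(C(=O)NCc4ccc(C(=O)Nc5ccccc5N)cc4)cc23)c1`) at 250 nM, so the three cannot be ranked.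

The next change leads to compound 4 (`COc1ccc(-c2cn(C)c(=O)c3[nH]c(C(=O)NCc4ccc(C(=O)Nc5ccccc5N)cc4)cc23)cc1`): 4-methoxyphenyl in place of 3-chlorophenyl on an aromatic carbon. In words, 4-methoxyphenyl stands in place of 3-chlorophenyl on an aromatic carbon of the shared core.

Among the compounds with values here, three measured steps bear on this change. The closest is the exchange of the same two substituents in the opposite sense, chloro in place of methoxy, which gave a 1.3-fold lower number from compound 1 to compound 3 (0.12 log units; within the scatter). Fluoro in place of methoxy gave a 1.2-fold lower number from compound 1 to compound 2 (0.08 log units; within the scatter), and chloro in place of fluoro gave a 1.1-fold lower number from compound 2 to compound 3 (0.04 log units; within the scatter). All three are small, so the aryl substituents tried so far have barely moved the read-out. Within the data shown here, the data hold no measured step for the 4-methoxyphenyl group itself, which widens the uncertainty.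

No step beyond the scatter is expected, and the expected step is a 1.3-fold higher number from compound 3 to compound 4 (0.10 log units; within the scatter). For compound 4 the estimated value is 240 nM, with an expected range from 120 nM to 480 nM.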

Compound 4, half-maximal inhibitory concentration: 320 nM
The estimate for compound 4 lay 1.3-fold (0.12 log units) below the measured number, and the stated range covers the measured number.
By their numbers in this assay, from the lowest: compounds 3, 2, 1 and 4 (each within the scatter of the next).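

In this assay, within the data shown here, the step from 3-methoxyphenyl to 4-methoxyphenyl is the first that keeps the substituent and changes only where it sits on the phenyl ring, and it gives a 1.3-fold higher number from compound 1 to compound 4 (0.11 log units; within the scatter). The other two exchanges at this aromatic carbon of the shared core give a 1.5-fold higher number from compound 2 to compound 4 (0.18 log units; within the scatter) and a 1.7-fold higher number from compound 3 to compound 4 (0.23 log units; within the scatter), so all three new steps stay within the scatter, and the 4-methoxyphenyl compound cannot be ranked against the three 3-substituted phenyl compounds. Nothing available explains these small steps or shows whether they reflect any real difference between the groups.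

As far as these compounds go, the four compounds cover only methoxy, fluoro and chloro on the phenyl ring, so it remains open whether an amine, a carboxylic acid or a longer alkoxy chain there would produce a step beyond the scatter. From the compounds shown here alone, with a single pair comparing the two substituent sites, and that pair within the scatter, it also remains open whether the site of substitution matters at all for this read-out.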